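Replacing the benzyl ether of compound 2 with a methallyl ether

The compounds below may be only part of what the source reports. "The series", "measured", "known", "first", "only" and "open" are said of these compounds alone.

Compound 2 `C[C@H]1C=C2C=C[C@H](C)[C@H](CCC3C[C@@H](O)CC(=O)O3)[C@H]2[C@@H](OCc2ccccc2)C1` gives 27 nM in an assay for inhibition of 3-hydroxy-3-methylglutaryl-coenzyme A reductase (Rattus norvegicus) (on this read-out lower numbers stand for stronger inhibition and higher numbers for weaker inhibition), the lowest of the two numbers recorded. Among the measured compounds shown here, its only neighbour is compound 1 `CC(=O)O[C@H]1C[C@@H](C)C=C2C=C[C@H](C)[C@H](CCC3C[C@@H](O)CC(=O)O3)[C@H]21`, which in this assay gives 269 nM. For the measured compounds named here, the one measured step, a 10-fold lower number from compound 1 to compound 2 (1.00 log units; beyond the scatter), is a modest change at the oxygen on a saturated carbon, so the substituent on that oxygen does shift the numbers in this assay.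

Compound 3 `C=C(C)CO[C@H]1C[C@@H](C)C=C2C=C[C@H](C)[C@H](CCC3C[C@@H](O)CC(=O)O3)[C@H]21` keeps everything else and differs from compound 2 as follows: 1-methylethenyl in place of phenyl on a saturated chain carbon bound to an oxygen on a saturated carbon. Going by the values given here, no measured pair shows phenyl against 1-methylethenyl at this position, so the step from compound 1 to compound 2 bears on it only by showing that the group on this oxygen matters; it does not say which way a smaller open-chain group would move the number. He therefore expects compound 3 to land near compound 2, with a small rise toward a higher number that may stay within the scatter, a 2.2-fold higher number from compound 2 to compound 3 (0.35 log units; beyond the scatter). His estimate for compound 3 is 60 nM, in the range 20 nM to 180 nM.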

Compound 3, half-maximal inhibitory concentration: 360 nM
Compound 3: the middle estimate sits 6.0-fold (0.78 log units) below what was measured, and the stated range ends below it.
By their numbers in this assay, from the lowest: compound 2; then compounds 1 and 3 (each within the scatter of the next).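

In this assay, exchanging phenyl for 1-methylethenyl on a saturated chain carbon bound to an oxygen on a saturated carbon gives a large step, a 13-fold higher number from compound 2 to compound 3 (1.12 log units; beyond the scatter), so the lower number seen with benzyl does not extend to every ether group on this oxygen. Against acetyl, the 2-methylprop-2-en-1-yl group gives a 1.3-fold higher number from compound 1 to compound 3 (0.13 log units; within the scatter), which lies within the scatter, so replacing acetyl with an ether group does not by itself move the number, and of the three groups only benzyl stands apart. Nothing at hand explains why the benzyl group behaves differently from the other two.

As far as these compounds go, whether the phenyl ring itself is what counts or any ring on this chain carbon would serve remains open, and a cyclohexylmethyl or a pyridylmethyl group on the oxygen would separate those readings. Also open, from the compounds shown here alone, is how a longer chain such as 2-phenylethyl, a saturated chain such as 2-methylpropyl, or a chain ending in an amine would compare with compound 2 and compound 3 on this oxygen.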